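Methylation of a catechol hydroxyl in the bromo series

A few compounds are considered here, and "the series" means these few. Any claim that something is new, unique, unknown or untested is made for them only; others in the source may bear on it.

Compound 2 `O=C(O)Cn1c(=O)c(/C=C/c2ccc(O)c(O)c2)nc2cc(Br)cnc21` stands highest of the two compounds measured in a functional assay, read by spectrophotometry, with a stated time of 30 min, tested at 100 uM (a lower number here means a weaker effect, a higher number a stronger effect of the compound at the concentration tested), where compound 2 gives 95.8%. The nearest is compound 1 `COc1cc(/C=C/c2nc3cccnc3n(CC(=O)O)c2=O)ccc1O`, which in this assay gives 85.5%, a gap beyond the usual scatter. Compound 3 `COc1cc(/C=C/c2nc3cc(Br)cnc3n(CC(=O)O)c2=O)ccc1O` is not yet measured. The change from compound 2 to compound 3 is methyl in place of hydrogen on an oxygen on an aromatic ring, hydroxy to methoxy, 3,4-dihydroxyphenyl to 4-hydroxy-3-methoxyphenyl. Among the compounds with values here, no step between measured compounds is available for this change. A modest loss is expected, since compound 1 carries the same 4-hydroxy-3-methoxyphenyl and gives 85.5%. The expected step is a number 7.8 percentage points lower from compound 2 to compound 3 (within the scatter), downward, at the edge of the scatter. For compound 3 the expected value in this assay is 88%, within 78% to 96%.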

Compound 3, a percentage reported as activity, at one concentration (the size of the read-out at that concentration, not a potency): 90.1%
Beside the measured number, compound 3's estimate is 2.1 percentage points below it; measured number inside the range.
By their numbers in this assay, from the lowest: compounds 1, 3 and 2 (each within the scatter of the next, the first and the last beyond it).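

In this assay the change from hydroxy to methoxy in the bromo series is a number 5.7 percentage points lower from compound 2 to compound 3 (within the scatter) and so does not show the free second hydroxy of 3,4-dihydroxyphenyl to be needed at this concentration. With 4-hydroxy-3-methoxyphenyl held fixed, bromo in place of hydrogen on an aromatic carbon is a number 4.6 percentage points higher from compound 1 to compound 3 (within the scatter) and so adds no separable effect. No measurement available here explains either step.

Still open, from the compounds shown here alone, is whether an ethyl or a longer chain on this oxygen keeps the read-out. An amine in place of this hydroxy also remains untested in the compounds shown, and a single concentration gives no potency for any of them.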